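Benzylamine substituent swap: fluoro to methoxy on the phenyl

The source may hold more compounds than are shown below. What is called first, only, known or untested is meant among the compounds shown, and "the series" means these compounds.

Compound 3 `Nc1cc(N)c2nc(-c3ccccc3)c(NCc3ccc(F)cc3)nc2c1` gives 29500 nM in a functional assay on UACC-62 cells (Homo sapiens) for inhibition, read by sulforhodamine B assay, with a stated time of 48 h; a higher number here means a weaker inhibitor of growth, a lower number a stronger inhibitor of growth. Compound 1 `Nc1cc(N)c2nc(-c3ccccc3)c(NCc3ccc(Cl)c(Cl)c3)nc2c1` gives 30900 nM in this assay, and compound 2 `COc1ccc(CNc2nc3cc(N)cc(N)c3nc2-c2ccccc2)cc1OC` gives 26300 nM; all three numbers lie within the scatter of one another, so compound 3 holds no separate position among them. Compound 4 `COc1ccc(CNc2nc3cc(N)cc(N)c3nc2-c2ccccc2)cc1` differs from compound 3 by methoxy in place of fluoro on an aromatic carbon. For the measured compounds named here, the steps bearing on this change are a 1.0-fold lower number from compound 1 to compound 3 (0.02 log units; within the scatter), a 1.2-fold lower number from compound 1 to compound 2 (0.07 log units; within the scatter) and a 1.1-fold higher number from compound 2 to compound 3 (0.05 log units; within the scatter), each within the scatter; no measured pair trades a single fluoro for a single methoxy. Changing the substituent on this phenyl has so far left this assay unmoved, so for compound 4 the expected step is a 1.1-fold lower number from compound 3 to compound 4 (0.02 log units; within the scatter), nothing beyond the scatter. The estimate for compound 4 in this assay is 28000 nM, with a range from 15000 nM to 55000 nM.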

Compound 4, concentration for total growth inhibition: 29500 nM
Beside the measured number, compound 4's estimate is 1.1-fold (0.02 log units) below it; measured number inside the range.
By their numbers in this assay, from the lowest: compounds 2, 3, 4 and 1 (each within the scatter of the next).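

Working from this assay, the first direct swap of 4-fluorophenyl to 4-methoxyphenyl stays within the scatter (no change at the digits printed from compound 3 to compound 4 (within the scatter)). The other two new pairs also stay within it, for one methoxy removed from the 3,4-dimethoxyphenyl (a 1.1-fold higher number from compound 2 to compound 4 (0.05 log units; within the scatter)) and for 4-methoxyphenyl in place of 3,4-dichlorophenyl (a 1.0-fold lower number from compound 1 to compound 4 (0.02 log units; within the scatter)), so all four compounds lie within the scatter of one another. No supporting data explain this flat response.

On these data alone, whether a carboxylic acid or an amine on this phenyl, or a longer chain in place of the benzyl group, would move the number beyond the scatter remains open. Changes elsewhere on the shared core also remain open.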